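The source may report more compounds than this note shows. Statements on the series, on what has been measured and on what is new or still open speak of the compounds shown alone.

In a functional assay (brain) for inhibition, with Rattus norvegicus as the target (a higher number here means a weaker inhibitor, a lower number a stronger inhibitor), compound 2 `CCCCNC(=O)C1CC(=O)c2cc(O)c(OC)cc2O1` gives 177000 nM, the highest of the three numbers recorded. Compound 1 `COc1cc2c(cc1O)CCC(C(=O)Nc1ccccc1)O2` gives 6900 nM and compound 3 `COc1cc2c(cc1O)CCC(C(=O)NCc1ccccc1)O2` gives 16600 nM, so both differ from compound 2 by gaps beyond the scatter. Compound 4 `COc1cc2c(cc1O)C(=O)CC(C(=O)NCc1ccccc1)O2` keeps the core of compound 2 and changes only the amide substituent: phenyl in place of propyl on a saturated chain carbon bound to an amide-type nitrogen. Within the data shown here, no measured step covers this exact swap. Among the measured compounds shown here, the one recorded step, a 2.4-fold higher number from compound 1 to compound 3 (0.38 log units; beyond the scatter), concerns benzyl against phenyl and is modest, so it only hints at how an aromatic group at the amide is tolerated. Compound 3, which carries benzyl, gives 16600 nM, which suggests the aromatic group may pull the number down. Compound 4 is therefore expected to show a step of a 3.9-fold lower number from compound 2 to compound 4 (0.59 log units; beyond the scatter), giving an estimated 45000 nM in this assay, with a range from 12000 nM to 170000 nM.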

Compound 4, half-maximal inhibitory concentration: > 300000 nM
Compound 4 ended at the assay's limit; the forecaster's own chance of this, stated with the estimate: 10%; middle value at least 6.6-fold (0.82 log units) away from the limit.
By their numbers in this assay, from the lowest: compound 1; then compound 3; then compound 2. At a limit, above all of these: compound 4.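

In this assay compound 4 gives > 300000 nM, which is a limit of the assay and not a number. On this core, benzyl in place of butyl brought no lower number, though only a floor can be read for the step: an at least 1.6-fold higher number from compound 2 to compound 4 (0.22 log units; that floor lies within the scatter). Compound 3, with the same benzyl on a different core, gives 16600 nM, so benzyl alone does not set the value.

As far as these compounds go, how far compound 4 lies past the limit stays open. So does whether a longer chain such as hexyl, or an amine on the benzyl ring, would lower the number on this core.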